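Phenyl Ether in Place of Benzyl Ether on a Shared Core

The source may report more compounds than this note shows. Statements on the series, on what has been measured and on what is new or still open speak of the compounds shown alone.

Compound 1 `C1=C(c2cncc(OCc3ccccc3)c2)CC2CNCC1C2`: 0.7 nM in an in vitro assay on SH-EP1 cells for displacement of a labelled ligand from Neuronal acetylcholine receptor; alpha4/beta2 (Homo sapiens); a higher number here means a weaker inhibitor, a lower number a stronger inhibitor
Compound 2 `C1=C(c2ccncc2)CC2CNCC1C2`: 56 nM
Compound 3 `COc1ccc(C2=CC3CC(C2)CN(C)C3)cn1`: 797 nM

Among the three measured compounds, compound 1 stands at the lowest number in this assay. Compound 2 gives a clearly higher number, and compound 3 gives a higher number still; both gaps lie beyond the usual scatter, so compound 1 is the strongest inhibitor of the three. Among the compounds with values here, no pair of measured compounds differs in a single place, so no measured step is available to anchor the change that leads to compound 4.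

Compound 4 `C1=C(c2cncc(Oc3ccccc3)c2)CC2CNCC1C2` arises from compound 1 by the change (phenyl in place of benzyl on an oxygen on an aromatic ring). With nothing measured for a change of this kind, the expectation rests on compound 1 alone, whose value of 0.7 nM leaves room for a rise. A modest rise in the number, somewhat beyond the scatter, is expected for the step of a 4.3-fold higher number from compound 1 to compound 4 (0.63 log units; beyond the scatter). Compound 4 is therefore estimated at 3 nM, with a range from 0.7 nM to 15 nM.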

Compound 4, inhibition constant: 0.7 nM
For compound 4 the middle estimate is 4.3-fold (0.63 log units) above the measured one; the measured number falls inside the stated range.
By their numbers in this assay, from the lowest: compounds 1 and 4 (each within the scatter of the next); then compound 2; then compound 3.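

In this assay, the change of benzyl to phenyl on an oxygen on an aromatic ring gives no change at the digits printed from compound 1 to compound 4 (within the scatter). Within the data shown here, this is the first measured step on the shared core, and it shows that this position accepts either group with no difference that can be told from the scatter. The two compounds therefore share the low end of the series, and the step gives no reason to prefer one group over the other. The data at hand offer no measurement that would explain this result.

On these data alone, whether this tolerance extends to other groups on the same oxygen remains open, for instance a longer chain such as phenethyl or a ring carrying a carboxylic acid. Among these compounds, also open is whether the oxygen itself matters, since no step shows it replaced by an amine or a sulfur atom.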